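Adding a Second Chloro to a Benzyl Group

This account rests on a few compounds, and the source may have more. Where it says the series, first, only, none or still open, it means among the compounds named here.

Measured so far in a functional assay on HEL cells (Homo sapiens) for inhibition; on this read-out higher numbers stand for lower toxicity in this test and lower numbers for higher toxicity in this test:
Compound 1, `O=C1c2ccccc2N(Cc2ccccc2)S(=O)(=O)N1COCc1ccccc1`, gives > 98000 nM, which is a limit of the assay.
Compound 2, `O=C1c2ccccc2N(Cc2cccc(Cl)c2)S(=O)(=O)N1Cc1ccccc1`, gives > 200000 nM, also a limit of the assay.
Compound 3, `O=C(OCOCN1c2ccccc2C(=O)N(Cc2ccccc2)S1(=O)=O)c1ccccc1`, gives 37000 nM.

Within the data shown here, compound 2 stands at the limit of > 200000 nM in this assay, at which 1 of the 3 values shown sits, so for it the assay reports no number, only that the value lies beyond its range. Compound 1 stands at the limit of > 98000 nM in this assay, at which 1 of the 3 values shown sits, another limit. Only compound 3 gives an actual number, 37000 nM. Among the measured compounds shown here, no two of these three compounds differ in just one place, so no measured step exists that could show how a single change moves the read-out.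

Compound 4, `O=C1c2ccccc2N(Cc2ccc(Cl)c(Cl)c2)S(=O)(=O)N1Cc1ccccc1`, has not yet been measured. It differs from compound 2 by chloro in place of hydrogen on an aromatic carbon.

For the measured compounds named here, with no measured step to lean on, the expectation rests only on where compound 2 stands. Compound 4 is estimated to give 150000 nM, expected between 40000 nM and 300000 nM. The expected step of an at least 1.3-fold lower number from compound 2 to compound 4 (0.12 log units; that floor lies within the scatter) is none beyond the scatter, and a limit rather than a number would not be surprising.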

Compound 4, half-maximal cytotoxic concentration: > 200000 nM
Compound 4 was reported as a limit (the forecaster's own chance of this, stated with the estimate: 55%); middle value at least 1.3-fold (0.12 log units) away from the limit.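

Compound 2 and compound 4 both give a limit rather than a number, so no step between them can be read: the limit of > 200000 nM in this assay, at which 2 of the 4 values shown sit.

The compounds shown leave open whether the change from 3-chlorobenzyl to 3,4-dichlorobenzyl moves the read-out in this assay at all, and if so, in which direction.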